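The source may hold more compounds than are shown below. What is called first, only, known or untested is meant among the compounds shown, and "the series" means these compounds.

Three compounds share one core and differ only in the group on a saturated chain carbon bound to a sulfur. Compound 1 `C/C(C#Cc1ccccc1)=N\N/C(N)=N/S(=O)(=O)c1cc(C)c(Cl)cc1SCc1cccc(C(F)(F)F)c1` gives 20000 nM in a functional assay on MCF7 cells (Homo sapiens) for antiproliferative activity, read by MTT assay, with a stated time of 72 h; on this read-out higher numbers stand for weaker inhibition and lower numbers for stronger inhibition. Compound 2 `C/C(C#Cc1ccccc1)=N\N/C(N)=N/S(=O)(=O)c1cc(C)c(Cl)cc1SCc1ccc(C(F)(F)F)cc1` gives 135000 nM, a step of a 6.8-fold higher number from compound 1 to compound 2 (0.83 log units; beyond the scatter). Compound 3 `C/C(C#Cc1ccccc1)=N\N/C(N)=N/S(=O)(=O)c1cc(C)c(Cl)cc1SCc1cccc(Cl)c1` gives 80000 nM, the second highest of the three numbers; its step from compound 1 is a 4.0-fold higher number from compound 1 to compound 3 (0.60 log units; beyond the scatter), while a 1.7-fold lower number from compound 2 to compound 3 (0.23 log units; within the scatter) lies within the scatter.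

Compound 4 `C/C(C#Cc1ccccc1)=N\N/C(N)=N/S(=O)(=O)c1cc(C)c(Cl)cc1SCc1cccc2ccccc12` carries the change (naphthalen-1-yl in place of 3-chlorophenyl on a saturated chain carbon bound to a sulfur). Within the data shown here, no measured step puts a naphthalen-1-yl at this place, so the direction of the step is not known from the data. The measured steps at this place, from compound 1 to compound 2 and from compound 2 to compound 3, move the number by modest amounts at most, and the whole spread across the three compounds is not large. The step from compound 3 to compound 4 is therefore expected to stay small, a 1.3-fold lower number from compound 3 to compound 4 (0.12 log units; within the scatter), with no clear direction. Compound 4 is estimated at 60000 nM, between 15000 nM and 250000 nM.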

Compound 4, half-maximal inhibitory concentration: 210000 nM
For compound 4 the middle estimate is 3.5-fold (0.54 log units) below the measured one; low and high end bracket the measured number.
By their numbers in this assay, from the lowest: compound 1; then compounds 3, 2 and 4 (each within the scatter of the next, the first and the last beyond it).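

In this assay, the larger naphthalen-1-yl, with its second aromatic ring, gives weaker inhibition than 3-chlorophenyl at this place, a 2.6-fold higher number from compound 3 to compound 4 (0.42 log units; beyond the scatter), and the step from the best group so far is the largest in the set, an 11-fold higher number from compound 1 to compound 4 (1.02 log units; beyond the scatter). Against 4-(trifluoromethyl)phenyl there is no telling the two groups apart, a 1.6-fold higher number from compound 2 to compound 4 (0.19 log units; within the scatter), so compound 1, with its 3-(trifluoromethyl)phenyl, remains the most potent of the four. No measurement at hand explains why these groups differ.

Still open, on these data alone, is whether any group on this saturated chain carbon can bring the number below that of compound 1, for example a pyridinyl ring, a cyclohexyl ring or a longer chain ending in an amine. All four compounds share one core, so they cannot show whether this order holds on a different core.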